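Dropping the chloro on the pyridine of a phosphate prodrug

This account rests on a few compounds, and the source may have more. Where it says the series, first, only, none or still open, it means among the compounds named here.

Measured so far:
compound 1, `Cc1cn([C@H]2C[C@H](N=[N+]=[N-])[C@@H](COP(=O)(O)Oc3cccnc3Cl)O2)c(=O)[nH]c1=O`, 16.3 h
compound 2, `O=c1ccn([C@H]2CC[C@@H](COP(=O)(O)Oc3ccncc3)O2)c(=O)[nH]1`, 23.6 h

Both compounds were tested in a physicochemical assay for metabolic stability, read by HPLC; a lower number here means that the compound disappears faster, a higher number that the compound lasts longer. Compound 1 gives 16.3 h, and compound 2 gives 23.6 h; the two numbers lie within the usual scatter of each other, so neither can be said to last longer than the other. Among the compounds with values here, compound 1 is the only one of the pair that carries a chloro on its pyridine ring and an azido on the sugar.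

Compound 3, `Cc1cn([C@H]2C[C@H](N=[N+]=[N-])[C@@H](COP(=O)(O)Oc3cccnc3)O2)c(=O)[nH]c1=O`, has not yet been measured. It differs from compound 1 in one place: hydrogen in place of chloro on an aromatic carbon. Within the data shown here, no measured pair shows what this change alone does to the half-life, so the only guide is the closeness of compounds 1 and 2, which differ in several places yet give similar numbers.

For compound 3 the step of a 1.1-fold higher number from compound 1 to compound 3 (0.04 log units; within the scatter) is expected to stay within the scatter. Compound 3 is therefore estimated at 18 h, between 9 h and 36 h.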

Compound 3, half-life: 3.88 h
Compound 3: the middle estimate sits 4.6-fold (0.67 log units) above what was measured; the measured number lies below the stated range.
By their numbers in this assay, from the lowest: compound 3; then compounds 1 and 2 (each within the scatter of the next).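

In this assay, the exchange of chloro for hydrogen on an aromatic carbon, next to the ring nitrogen, gives a 4.2-fold lower number from compound 1 to compound 3 (0.62 log units; beyond the scatter). Within the data shown here, this is the first comparison here in which only one place changes, and it shows that, on this core, going from 2-chloropyridin-3-yl to pyridin-3-yl shortens the half-life by more than the usual scatter. Nothing at hand accounts for why this single exchange has such an effect.

As far as these compounds go, whether chloro is special at this position remains open, since a fluoro, a methyl or a methoxy group in the same place could show whether other groups give a similar half-life. From the compounds shown here alone, it is also open whether the same exchange would shift the half-life on a core without the azido group.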